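The compounds below may be only part of what the source reports. "The series", "measured", "known", "first", "only" and "open" are said of these compounds alone.

Compound 1 `COc1ccc2c(=O)c(/C=C/C(=O)NCc3ccccc3)coc2c1` — in a functional assay (QGY7701 cells, Homo sapiens) for inhibition, read by MTT assay, with a stated time of 48 h (a lower number here means a stronger inhibitor, a higher number a weaker inhibitor), compound 1 gives > 100000 nM, which is a limit of the assay and not a number.
Compound 2 `COc1ccc2c(=O)c(/C=C/C(=O)Nc3ccccc3Cl)coc2c1` — compound 2 gives 23000 nM.
Compound 3 `COc1ccc2c(=O)c(/C=C/C(=O)Nc3ccccc3OC)coc2c1` — compound 3 gives 17600 nM.

Compound 1 is the only one of the three that reaches no number; it sits at the limit of > 100000 nM in this assay, at which 1 of the 3 values shown sits, so it stands as the weakest of the measured compounds, with the two aryl amides below it. Compound 4 `COc1ccc2c(=O)c(/C=C/C(=O)Nc3ccc(F)cc3)coc2c1` has not yet been measured. It differs from compound 1 as follows: 4-fluorophenyl in place of benzyl on an amide-type nitrogen.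

Going by the values given here, two measured steps bear on this change, since both also replace benzyl with a substituted phenyl on the same amide-type nitrogen: an at least 4.3-fold lower number from compound 1 to compound 2 (0.63 log units; beyond the scatter) and an at least 5.6-fold lower number from compound 1 to compound 3 (0.75 log units; beyond the scatter). Between the two aryl amides themselves, a 1.3-fold lower number from compound 2 to compound 3 (0.12 log units; within the scatter), so the nature of the substituent on the ring made little difference there. A step of comparable size and in the same direction is therefore expected for compound 4, namely an at least 4.0-fold lower number from compound 1 to compound 4 (0.60 log units; beyond the scatter). Compound 4 is estimated at 25000 nM, with a range from 8000 nM to 80000 nM.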

Compound 4, half-maximal inhibitory concentration: > 100000 nM
Compound 4 gave a limit, no number; the forecaster's own chance of this, stated with the estimate: 15%; middle value at least 4.0-fold (0.60 log units) away from the limit.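

In this assay, replacing the substituted phenyl groups with 4-fluorophenyl gives an at least 5.6-fold higher number from compound 3 to compound 4 (0.75 log units; beyond the scatter) and an at least 4.3-fold higher number from compound 2 to compound 4 (0.63 log units; beyond the scatter). The gain seen on going from benzyl to 2-chlorophenyl or 2-methoxyphenyl therefore does not extend to every aryl group on this amide-type nitrogen, and compound 4 goes against any rule that an aryl amide outperforms the benzyl amide. The step between compound 1 and compound 4 cannot be read, and the two cannot be ranked against each other: the limit of > 100000 nM in this assay, at which 2 of the 4 values shown sit.

Compound 4 differs from compound 2 and compound 3 in both the substituent and its place on the ring, so the compounds shown do not separate these two changes. Going by these compounds, what 2-fluorophenyl or 4-methoxyphenyl on the same nitrogen would give in this assay remains open.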